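The source may hold more compounds than are shown below. What is called first, only, known or untested is meant among the compounds shown, and "the series" means these compounds.

Compound 1 is `CCOC(=O)C1=Cc2ccccc2OC1(OCc1cn(CC(=O)Nc2ccccc2Br)nn1)C(F)(F)F`. It was tested in a functional assay on HeLa cells (Homo sapiens) for inhibition, read by MTT assay, with a stated time of 24 h; a higher number here means a weaker inhibitor, a lower number a stronger inhibitor. There compound 1 gives only a limit, > 150000 nM, not a measured number. The other measured member of the set, compound 2, is `CCOC(=O)C1=Cc2ccccc2OC1(OCc1cc(-c2ccc([N+](=O)[O-])cc2)no1)C(F)(F)F`. In this assay compound 2 likewise reaches only a limit, > 150000 nM. Compound 1 therefore cannot be placed on a scale; what is known of the set is the limit of > 150000 nM in this assay, at which 2 of the 2 values shown sit, and the two shown values do not separate from one another. For the measured compounds named here, no pair of measured compounds differs in a single place, so no measured step is available. The compound not yet measured, compound 3, is `CCOC(=O)C1=Cc2ccccc2OC1(OCc1cn(CC(=O)Nc2ccc(OC)cc2)nn1)C(F)(F)F`. It differs from compound 1 by 4-methoxyphenyl in place of 2-bromophenyl on an amide-type nitrogen. Because the limit of > 150000 nM in this assay, at which 2 of the 2 values shown sit, describes the whole of the shown data, the step from compound 1 to compound 3 in this assay is expected to be none beyond the scatter, and a limit is expected again. The estimate for compound 3 is 200000 nM, within 80000 nM to 600000 nM. The step this estimate means, a step that the limit leaves unreadable from compound 1 to compound 3, is expected to lie within the scatter.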

Compound 3, half-maximal inhibitory concentration: 31900 nM
Estimate against measurement, compound 3: 6.3-fold (0.80 log units) above; measured number outside the range, below it.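

In this assay, 4-methoxyphenyl in place of 2-bromophenyl on the amide-type nitrogen gives an at least 4.7-fold lower number from compound 1 to compound 3 (0.67 log units; beyond the scatter), which shows that the group at this position can move the result beyond the scatter. Compound 3, at 31900 nM, gives the only measured number among the compounds shown, so a compound with this shared core can give a reading in this assay rather than a limit. The size of the step remains a bound, and the other two compounds remain at a limit, not a number: the limit of > 150000 nM in this assay, at which 2 of the 3 values shown sit.

The compounds shown leave open whether the step follows from the loss of the bromine, the presence of the methoxy group or the different place of the group on the phenyl ring, since all three change together between compound 1 and compound 3. On these data alone, a plain phenyl, a 4-bromophenyl or a 2-methoxyphenyl on the same nitrogen would begin to separate these, and how much further the number can fall at this position also remains open.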